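Chloro for Methoxy on the Anilide Ring

The source may hold more compounds than are shown below. What is called first, only, known or untested is meant among the compounds shown, and "the series" means these compounds.

Measured so far:
compound 1, `Cc1cccc(-c2cccc(NC(=O)c3nnc(CCC(=O)O)s3)c2)c1`, 760 nM
compound 2, `O=C(O)CCc1nnc(C(=O)Nc2cccc(-c3ccc(F)cc3)c2)s1`, 1280 nM
compound 3, `COc1ccc(NC(=O)c2nnc(COc3ccc(CCC(=O)O)cc3)s2)cc1`, > 10000 nM

In a functional assay on CHO cells for agonist activity at Free fatty acid receptor 1 (Homo sapiens), read by calcium flux (a higher number here means that more compound is needed for the effect, a lower number that less compound is needed), compound 1 gives 760 nM. Compound 2 gives 1280 nM in this assay, and the step of a 1.7-fold higher number from compound 1 to compound 2 (0.23 log units; within the scatter). For compound 3 this assay reports only a limit, > 10000 nM; compound 3 therefore stands at the weak end of the measured set, at the limit of > 10000 nM in this assay, at which 1 of the 3 values shown sits.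

Compound 4, `O=C(O)CCc1ccc(OCc2nnc(C(=O)Nc3ccc(Cl)cc3)s2)cc1`, differs from compound 3 by chloro in place of methoxy on an aromatic carbon. Among the compounds with values here, no measured step touches this position or this exchange: the only measured step, from compound 1 to compound 2, changes a different ring and was within the scatter, so it gives no guide for the direction here. Since compound 3 sits at the limit, compound 4 is expected to remain weak, with a step of an at least 1.2-fold lower number from compound 3 to compound 4 (0.09 log units; that floor lies within the scatter) that the limit of compound 3 cannot confirm. The estimate for compound 4 in this assay is 8000 nM, between 2000 nM and 30000 nM.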

Compound 4, half-maximal effective concentration: 3690 nM
Compound 4: middle estimate off by 2.2-fold (0.34 log units), on the high side; low and high end bracket the measured number.
By their numbers in this assay, from the lowest: compounds 1 and 2 (each within the scatter of the next); then compound 4. At a limit, above all of these: compound 3.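

Setting the 4-chlorophenyl in place of the 4-methoxyphenyl gives the first change in this set that is read as lying beyond the scatter: in this assay, the result is an at least 2.7-fold lower number from compound 3 to compound 4 (0.43 log units; beyond the scatter). The exchange therefore turns a limit into a measured number, and it shows that this position on the ring can affect the read-out. The step is only a floor, because compound 3 stands at a limit of the assay: the limit of > 10000 nM in this assay, at which 1 of the 4 values shown sits.

Whether chloro is special at this place remains open, since the compounds shown do not include bromo, a nitrile or an amine there. From the compounds shown here alone, compounds 1 and 2 differ from compound 4 in more than one place, so it also remains open how the chain carrying the carboxylic acid contributes to these values.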